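The compounds below may be only part of what the source reports. "The series", "measured", "known", "first", "only" and "open" are said of these compounds alone.

Compound 1, `OC[C@H]1O[C@@H](n2cnc3c(NCc4ccccc4Cl)ncnc32)[C@H](O)[C@@H]1O` — "not determined" (no result reported)
Compound 2, `OC[C@H]1O[C@@H](n2cnc3c(NCc4cccc(Br)c4)ncnc32)[C@H](O)[C@@H]1O` — > 166000 nM

Two compounds share the core shown above and carry a different benzyl group on the exocyclic nitrogen. In a functional assay on G-361 cells (Homo sapiens) for antiproliferative activity, with a stated time of 72 h (on this read-out higher numbers stand for weaker inhibition and lower numbers for stronger inhibition), compound 1 returns "not determined" (no result reported), so no number is known for it. In this assay compound 2 returns only a limit, > 166000 nM, and not a number. Among the measured compounds shown here, compound 2 therefore sits at the edge of what the assay reports, as the line the limit of > 166000 nM in this assay, at which 1 of the 2 values shown sits, shows; no measured step is available for comparison.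

The unmeasured compound is compound 3, `OC[C@H]1O[C@@H](n2cnc3c(NCc4ccc(F)cc4Cl)ncnc32)[C@H](O)[C@@H]1O`. It differs from compound 2 in one place: 2-chloro-4-fluorophenyl in place of 3-bromophenyl on a saturated chain carbon bound to a nitrogen on an aromatic ring.

For the measured compounds named here, with no measured step to draw on, the estimate for compound 3 rests on the limit of compound 2 alone. The expected step of an at least 1.1-fold lower number from compound 2 to compound 3 (0.04 log units; that floor lies within the scatter) is small, within the scatter, with no direction favoured. Compound 3 is thus estimated at 150000 nM, with a range from 30000 nM to 600000 nM, and a high chance that this assay again reports only a limit.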

Compound 3, half-maximal inhibitory concentration: > 166000 nM
Compound 3 was reported as a limit (the forecaster's own chance of this, stated with the estimate: 70%); middle value at least 1.1-fold (0.04 log units) away from the limit.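

In this assay compound 3 returns only a limit of > 166000 nM and not a number. Among the compounds shown here, compound 2 also stands at a limit, so no step between compound 2 and compound 3 can be read. The compounds shown leave open whether any benzyl group on the shared core gives a measurable number in this assay at all.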